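This account rests on a few compounds, and the source may have more. Where it says the series, first, only, none or still open, it means among the compounds named here.

Working notes on the series.

Compound 1 `Cc1cccc2c1CCCC2c1c[nH]cn1` serves as the starting point. In an assay on cell membranes for displacement of a labelled ligand from Adrenergic receptor alpha-1 (Rattus norvegicus) (a lower number here means a stronger inhibitor, a higher number a weaker inhibitor), compound 1 gives 191 nM. Compound 2 `Cc1cc(C)c2c(c1)C(c1c[nH]cn1)CCC2` carries the change methyl in place of hydrogen on an aromatic carbon relative to compound 1, and in this assay compound 2 gives 131 nM. The step of a 1.5-fold lower number from compound 1 to compound 2 (0.16 log units; within the scatter) is within the scatter, so no order between compound 1 and compound 2 can be read from these two values.

Compound 3 `Cc1cccc2c1CCC=C2c1c[nH]cn1` has a different core; the difference between the core of compound 3 and the core of compound 1 is not broken down here. In this assay compound 3 gives 992 nM, the highest number of the three measured compounds, beyond the scatter against both compound 1 and compound 2.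

Compound 4 `Cc1cc(C)c2c(c1)C(c1c[nH]cn1)=CCC2` has not yet been measured. It stands to compound 3 as compound 2 stands to compound 1: the change methyl in place of hydrogen on an aromatic carbon is the same change as the one from compound 1 to compound 2, at the same place by every counted description, and it occurs twice among the compounds shown. Among the measured compounds shown here, the expectation for compound 4 therefore rests on the one measured instance of this change, the step of a 1.5-fold lower number from compound 1 to compound 2 (0.16 log units; within the scatter), carried over onto the core of compound 3. The step from compound 3 to compound 4 in this assay is expected to be a 1.5-fold lower number from compound 3 to compound 4 (0.18 log units; within the scatter), of about the same size as the earlier one and likewise within the scatter. For the measured compounds named here, on that basis compound 4 is estimated at 660 nM, with a range from 300 nM to 1500 nM, in which the single earlier instance of the change and the wider core difference both add uncertainty.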

Compound 4, inhibition constant: 2960 nM
Estimate against measurement, compound 4: 4.5-fold (0.65 log units) below, and the stated range ends below it.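

In this assay, methyl in place of hydrogen on an aromatic carbon gives a 3.0-fold higher number from compound 3 to compound 4 (0.47 log units; beyond the scatter), so on the core of compound 3 the change raises the number beyond the scatter. Set beside the earlier step, the same change at the same place does not carry over unchanged from the core of compound 1 to the core of compound 3, and a step read on one of these cores is therefore a poor guide to the other: the same change on two cores in this assay, a 1.5-fold lower number (0.16 log units; within the scatter) from compound 1 to compound 2 and a 3.0-fold higher number (0.47 log units; beyond the scatter) from compound 3 to compound 4, 4.4-fold (0.64 log units) apart, beyond the scatter of two such steps This shows that the outcome of the change depends on the core within these four compounds, but it rests on a single pair per core and does not show which feature of the core difference is responsible, nor that the dependence extends to any other core.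

Open, from the compounds shown here alone, is whether the same dependence on the core appears with other groups at this place, such as chloro, methoxy or a longer chain such as ethyl, or whether it is confined to methyl. Also open, going by these compounds, is whether an amine or a carboxylic acid at this place would separate the two cores in the same direction.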